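Swapping the benzyl group: will the half-life hold?

The compounds below may be only part of what the source reports. "The series", "measured", "known", "first", "only" and "open" are said of these compounds alone.

compound 1 `CS(=O)(=O)Nc1ccc2c(c1)S(=O)(=O)N=C(C1=C(O)[C@H]3CCC[C@H]3N(Cc3ccc(F)c(F)c3)C1=O)N2`: > 1 h
compound 2 `CS(=O)(=O)Nc1ccc2c(c1)S(=O)(=O)N=C(C1=C(O)[C@H]3CCC[C@H]3N(Cc3ccc(C(F)(F)F)cc3)C1=O)N2`: > 1 h

In an in vitro ADME assay on microsomes from liver (Homo sapiens) for metabolic stability (on this read-out lower numbers stand for a shorter-lived compound and higher numbers for a longer-lived compound), compound 1 gives > 1 h, which is a limit of the assay. Compound 2 likewise gives > 1 h, again a limit. Within the data shown here, the step that the two limits leave unreadable from compound 1 to compound 2 cannot be read, and the only evidence on the measured pair is the limit of > 1 h in this assay, at which 2 of the 2 values shown sit. Compound 3 `Cc1cc(CN2C(=O)C(C3=NS(=O)(=O)c4cc(NS(C)(=O)=O)ccc4N3)=C(O)[C@H]3CCC[C@H]32)ccc1F` differs from compound 2 by 4-fluoro-3-methylphenyl in place of 4-(trifluoromethyl)phenyl on a saturated chain carbon bound to an amide-type nitrogen in a ring. With no readable step to draw on, compound 3 is expected to remain close to the limit, so a step that the limit leaves unreadable from compound 2 to compound 3 is expected to be small. Compound 3 is estimated at 1.2 h, between 0.5 h and 3 h.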

Compound 3, half-life: > 1 h
Compound 3 ended at the assay's limit; the forecaster's own chance of this, stated with the estimate: 55%; the middle value does not contradict the limit.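

The steps among compound 1, compound 2 and compound 3 cannot be read, as all three values are the same limit: the limit of > 1 h in this assay, at which 3 of the 3 values shown sit.

As far as these compounds go, the actual half-life of each compound, and whether swapping the benzyl group changes it, stays open.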